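A few compounds are considered here, and "the series" means these few. Any claim that something is new, unique, unknown or untested is made for them only; others in the source may bear on it.

Measured in an ADME assay on microsomes from liver (Rattus norvegicus) for metabolic stability, with a stated time of 10 min (a lower number here means that less of the compound is left, a higher number that more of the compound is left), so far:
compound 1 `CCCCCNc1nc(Nc2ccc([N+](=O)[O-])cc2)nc(OCC(F)(F)F)n1` gives 35%
compound 2 `CC(C)(C)NC(=O)NCCS(=O)(=O)NC(=O)c1ccc(Nc2nc(NC3(c4ccc(Cl)cc4)CC3)nc(OCC(F)(F)F)n2)cc1` gives 93%
compound 3 `CC(C)(C)OC(=O)NCCS(=O)(=O)NC(=O)c1ccc(Nc2nc(NC3(c4ccc(Cl)cc4)CC3)nc(OCC(F)(F)F)n2)cc1` gives 93%

Compound 3 stands level with compound 2 in this assay, and the two share the top of this small set, while compound 1 sits far below both, beyond the scatter. Compound 4 `CC(C)OC(=O)NCCS(=O)(=O)NC(=O)c1ccc(Nc2nc(NC3(c4ccc(Cl)cc4)CC3)nc(OCC(F)(F)F)n2)cc1` carries the change (hydrogen in place of methyl on a saturated chain carbon bound to an oxygen next to a carbonyl group and two saturated chain carbons). Within the data shown here, the one measured step that bears on this end of the molecule, no change at the digits printed from compound 2 to compound 3 (within the scatter), exchanged the whole (tert-butyl)amino group for tert-butoxy on a carbonyl carbon and left the remaining fraction unmoved; the smaller trim of tert-butoxy to isopropoxy has no measured precedent here. Compound 4 is therefore expected to stay within the scatter of compound 3, with a number 3 percentage points lower from compound 3 to compound 4 (within the scatter) as the estimated step. The estimate for compound 4 is 90%, between 75% and 98%.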

Compound 4, percent of the compound remaining: 73%
Estimate against measurement, compound 4: 17 percentage points above; the whole stated range lies above it.
By their numbers in this assay, from the lowest: compound 1; then compound 4; then compounds 2 and 3 (each within the scatter of the next).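

In this assay the group on this carbonyl carbon turns out to matter: trimming tert-butoxy to isopropoxy gives a number 20 percentage points lower from compound 3 to compound 4 (beyond the scatter) and isopropoxy in place of (tert-butyl)amino gives a number 20 percentage points lower from compound 2 to compound 4 (beyond the scatter) although the earlier exchange gave no change at the digits printed from compound 2 to compound 3 (within the scatter) at this same place. Among these three compounds, the two carrying tert-butyl hold the higher numbers, so one methyl counts for more here than the exchange of nitrogen for oxygen did. Nothing shown accounts for this drop. Going by these compounds, whether ethoxy or methoxy lowers the number further, or a longer chain on this oxygen raises it, stays open. So does whether isopropylamino would follow isopropoxy.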